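The source may hold more compounds than are shown below. What is called first, only, known or untested is meant among the compounds shown, and "the series" means these compounds.

Measured compounds in hand:

Compound 1 `O=C(/C=C1\CCc2c(F)cc(F)cc21)NC1CC1`: 100%
Compound 2 `CC(C)NC(=O)/C=C1\CCc2ccc(F)cc21`: 100%
Compound 3 `CC(C)NC(=O)/C=C1\CCc2c(F)cc(F)cc21`: 100%

In a functional assay on the whole organism with Mus musculus as the target, at a dose of 100 mg/kg by the intraperitoneal route (on this read-out higher numbers stand for more inhibition at the one dose given (going by the name of the read-out) and lower numbers for less inhibition), compound 1 gives 100%, compound 2 gives 100% and compound 3 gives 100%. Compound 2 therefore stands level with compounds 1 and 3 at the digits shown; the whole series sits at the top of the read-out, and no compound can be called stronger than another.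

The next compound is compound 4 `O=C(/C=C1\CCc2ccc(F)cc21)N1CCC1`. Its difference from compound 2 is azetidin-1-yl in place of isopropylamino on a carbonyl carbon. Of the measured steps, no change at the digits printed from compound 1 to compound 3 (within the scatter) is the one that touches the amide-type nitrogen, and it was flat; no change at the digits printed from compound 2 to compound 3 (within the scatter), a change on the aromatic carbon, was flat as well. Neither step replaces the amide hydrogen with a ring closure, so the change to compound 4 is not covered directly. With every measured value at the ceiling, only a downward move is possible, and the flat steps give no reason to expect one beyond the scatter; the expected step is a number 10 percentage points lower from compound 2 to compound 4 (within the scatter). Compound 4 is estimated at 90%, in the range 55% to 100%.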

Compound 4, a percentage reported as inhibition, in the whole organism at one dose (the size of the read-out at that dose, not a potency): 33%
Estimate against measurement, compound 4: 57 percentage points above; the whole stated range lies above it.
By their numbers in this assay, from the lowest: compound 4; then compounds 1, 2 and 3 (each within the scatter of the next).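

In this assay, among these compounds, the substituent on the carbonyl carbon is the first place where a change moves the read-out off the ceiling: a number 67 percentage points lower from compound 2 to compound 4 (beyond the scatter), with azetidin-1-yl in place of isopropylamino. The two groups have the same count of heavy atoms, and differ in the four-membered ring and in the hydrogen-bond donor present only in isopropylamino, so this single step cannot separate the ring from the loss of the amide hydrogen. No measurement on hand bears on the reason for this step.

Open, going by these compounds, is whether dimethylamino, which also lacks the amide hydrogen but has no ring, would stay near compound 2 or fall towards compound 4. Also open, on these data alone, is whether a larger ring, such as pyrrolidin-1-yl, or a ring kept on an amide that retains its hydrogen, such as cyclobutylamino, would hold the read-out at the ceiling.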